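The source may report more compounds than this note shows. Statements on the series, on what has been measured and on what is new or still open speak of the compounds shown alone.

Three compounds of this series have numbers in a functional assay on the whole organism for inhibition, with Echinochloa esculenta as the target; on this read-out lower numbers stand for stronger inhibition and higher numbers for weaker inhibition. Compound 1 `S=c1n(-c2ccccc2)c(=S)n2n1CCCC2` gives 3550 nM. Compound 3 `Fc1cc(Cl)ccc1/N=c1\sc(=S)n2n1CCCC2` gives 158 nM. Compound 2 `CC(C)Oc1cc(-n2c(=S)n3n(c2=S)CCCC3)c(F)cc1Cl` gives 12.3 nM, the lowest number of the three; its steps to compound 3 and to compound 1 are both beyond the scatter, so compound 2 is the strongest inhibitor among those measured in this assay.

Compound 4 `C#CCOc1cc(-n2c(=S)n3n(c2=S)CCCC3)c(F)cc1Cl` is not yet measured. It differs from compound 2 in one place: propargyl in place of isopropyl on an oxygen on an aromatic ring. The ether oxygen, the halogens and the shared core are unchanged.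

For the measured compounds named here, no measured pair differs in exactly this way, so no step of this kind is known from the data. The change keeps the count of heavy atoms and replaces a branched saturated chain by a straight chain carrying a triple bond. On that ground a small step is expected, within or near the scatter, with no firm direction. Compound 4 is expected to give 18 nM, with a range of 5 nM to 60 nM, which means an estimated step of a 1.5-fold higher number from compound 2 to compound 4 (0.17 log units; within the scatter).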

Compound 4, half-maximal inhibitory concentration: 1.7 nM
The estimate for compound 4 lay 11-fold (1.02 log units) above the measured number; measured number outside the range, below it.
By their numbers in this assay, from the lowest: compound 4; then compound 2; then compound 3; then compound 1.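

For the compounds shown here, the oxygen on an aromatic ring is the first place where a single change can be read: in this assay, propargyl in place of isopropyl gives a 7.2-fold lower number from compound 2 to compound 4 (0.86 log units; beyond the scatter) and this step lies beyond the scatter. Both groups count 3 heavy atoms, so this position separates two chains of equal heavy-atom count, one branched and saturated, the other straight and carrying a triple bond. No measurement on these compounds accounts for the step.

Open, on these data alone, is whether a straight propyl chain on the same oxygen would read like propargyl or like isopropyl, which would separate the triple bond from the loss of branching. Also open, as far as these compounds go, is how a longer chain carrying a triple bond, or an amine in place of the ether, would read here.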